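A few compounds are considered here, and "the series" means these few. Any claim that something is new, unique, unknown or untested is made for them only; others in the source may bear on it.

Measured so far:
compound 1 `COc1ccc(CNc2nc3cc(N)cc(N)c3nc2-c2ccccc2)cc1OC` — 58900 nM
compound 2 `Nc1cc(N)c2nc(-c3ccccc3)c(NCc3ccc(F)cc3)nc2c1` — 64600 nM
compound 3 `COc1ccc(CNc2nc3cc(N)cc(N)c3nc2-c2ccccc2)cc1` — 58900 nM

In a functional assay on SF-295 cells (Homo sapiens) for inhibition, read by sulforhodamine B assay, with a stated time of 48 h (a higher number here means that more compound is tolerated, a lower number that less compound is tolerated), compound 2 holds the highest of the three numbers, yet both neighbours lie within the scatter: a 1.1-fold higher number from compound 1 to compound 2 (0.04 log units; within the scatter) and a 1.1-fold lower number from compound 2 to compound 3 (0.04 log units; within the scatter). The remaining pairing, no change at the digits printed from compound 1 to compound 3 (within the scatter), is likewise flat. Compound 4 `Nc1cc(N)c2nc(-c3ccccc3)c(Sc3ccc(Cl)c(Cl)c3)nc2c1` is unmeasured and differs from compound 2 by (3,4-dichlorophenyl)sulfanyl in place of (4-fluorobenzyl)amino on an aromatic carbon. None of the three measured steps touches this change: each swaps substituents on the aromatic ring of the benzyl group while the benzylamino linkage stays in place, whereas here the linkage itself is exchanged for a sulfanyl attachment. Within the data shown here, the flat steps show only that, within this set, substituents on that ring move the number by no more than the scatter; for the exchange of the linkage there is no precedent. The expected step is therefore a 1.3-fold lower number from compound 2 to compound 4 (0.11 log units; within the scatter), with a wide band to cover the untested change. Compound 4 is estimated at 50000 nM, within a range of 15000 nM to 150000 nM.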

Compound 4, concentration lethal to 50% of the cells: < 100000 nM
Compound 4: a limit, no number (the forecaster's own chance of this, stated with the estimate: 20%); the middle value does not contradict the limit.
By their numbers in this assay, from the lowest: compounds 1, 3 and 2 (each within the scatter of the next).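

In this assay compound 4 gives < 100000 nM, which is a limit and not a number. The step from compound 2 to compound 4 cannot be read. Still open, from the compounds shown here alone, is how far (3,4-dichlorophenyl)sulfanyl in place of (4-fluorobenzyl)amino moves the number in this assay.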